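Working notes on a bicyclic urea series: compound 4

The compounds below may be only part of what the source reports. "The series", "measured", "known", "first", "only" and "open" are said of these compounds alone.

Compound 1 `CC(C)N(CCN(C(=O)Nc1ccc(F)c(Cl)c1)C1CC[C@]2(c3cccc(C#N)c3)CC2C1)C(C)C` gives 4.98 nM in a functional assay for antagonist activity at melanin-concentrating hormone receptor 1 (Homo sapiens); a higher number here means a weaker inhibitor, a lower number a stronger inhibitor. Among the three measured compounds it holds the second highest number: compound 2 `CC(C)N(CCN(C(=O)Nc1ccc(F)c(F)c1)C1CC[C@]2(c3cccc(C#N)c3)CC2C1)C(C)C` gives 2.8 nM, and compound 3 `N#Cc1cccc([C@]23CCC(N(CCN4CCCC(O)C4)C(=O)Nc4ccc(F)c(Cl)c4)CC2C3)c1` gives 22 nM. The step of a 1.8-fold lower number from compound 1 to compound 2 (0.25 log units; within the scatter) concerns fluoro in place of chloro on an aromatic carbon; the step of a 4.4-fold higher number from compound 1 to compound 3 (0.65 log units; beyond the scatter) concerns 3-hydroxypiperidin-1-yl in place of diisopropylamino. Compound 4 `CC(C)N(CCN(C(=O)Nc1ccc(F)c(Cl)c1)C1CC[C@]2(c3cccc(CNS(C)(=O)=O)c3)CC2C1)C(C)C` differs from compound 1 by (methanesulfonamido)methyl in place of cyano on an aromatic carbon. Among the measured compounds shown here, neither measured step touches this part of the shared core, so neither bears on the change, and no step of a comparable kind has been measured. For the measured compounds named here, the expectation for compound 4 therefore rests on no precedent; a modest rise, a 3.0-fold higher number from compound 1 to compound 4 (0.48 log units; beyond the scatter), is expected in this assay. Compound 4 is estimated at 15 nM, with a range from 3 nM to 80 nM.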

Compound 4, inhibition constant: 18 nM
Estimate against measurement, compound 4: 1.2-fold (0.08 log units) below; measured number inside the range.
By their numbers in this assay, from the lowest: compounds 2 and 1 (each within the scatter of the next); then compounds 4 and 3 (each within the scatter of the next).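

In this assay, among the compounds shown here, replacing cyano with (methanesulfonamido)methyl gives a 3.6-fold higher number from compound 1 to compound 4 (0.56 log units; beyond the scatter), the first reading of a change at this position on the aromatic ring. The position accepts this larger group, which brings a hydrogen-bond donor, at a modest cost, so the cyano group is not required for activity in the nanomolar range. Nothing available accounts for the rise.

On these data alone, whether a simple aminomethyl group or a carboxylic acid would read closer to cyano stays open. So does whether the same change would give a similar step on compound 2.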